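From furan-3-yl to ethynyl on the shared core

The source may report more compounds than this note shows. Statements on the series, on what has been measured and on what is new or still open speak of the compounds shown alone.

Going by the values given here, in a functional assay on HepG2 cells (Homo sapiens) for antiproliferative activity, read by XTT assay, with a stated time of 72 h (on this read-out lower numbers stand for stronger inhibition and higher numbers for weaker inhibition), compound 3 `CN(C)c1ncnc2c1c(-c1ccoc1)cn2[C@@H]1O[C@H](CO)[C@@H](O)[C@H]1O` gives 12500 nM, the only exact number among the three values. Compound 1 `CSc1ncnc2c1c(-c1ccoc1)cn2[C@@H]1O[C@H](CO)[C@@H](O)[C@H]1O` is reported only as a limit, > 15000 nM. Compound 2 `CNc1ncnc2c1c(-c1ccoc1)cn2[C@@H]1O[C@H](CO)[C@@H](O)[C@H]1O` is also reported only as a limit, > 20000 nM. Compound 4 `C#Cc1cn([C@@H]2O[C@H](CO)[C@@H](O)[C@H]2O)c2ncnc(N(C)C)c12` has not yet been measured, and it carries ethynyl in place of furan-3-yl on an aromatic carbon. Among the compounds with values here, all the measured steps keep furan-3-yl and change another place. The floors of an at least 1.2-fold lower number from compound 1 to compound 3 (0.07 log units; that floor lies within the scatter) and an at least 1.6-fold lower number from compound 2 to compound 3 (0.20 log units; that floor lies within the scatter) lie within the scatter, and a step that the two limits leave unreadable from compound 1 to compound 2 cannot be read. None of them tests this exchange, so the expectation rests on compound 3 with its 12500 nM alone, and no step beyond the scatter is expected in this assay. The estimated change is a 1.4-fold lower number from compound 3 to compound 4 (0.14 log units; within the scatter). Compound 4 is expected at 9000 nM, within an estimated range of 1500 nM to 30000 nM.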

Compound 4, half-maximal inhibitory concentration: 1320 nM
For compound 4 the middle estimate is 6.8-fold (0.83 log units) above the measured one, outside the stated range (below it).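

The exchange of furan-3-yl for ethynyl on this aromatic carbon, two ring bonds from the ring nitrogen, gives a 9.5-fold lower number from compound 3 to compound 4 (0.98 log units; beyond the scatter) in this assay and so changes the read-out clearly. The earlier steps shown here all kept furan-3-yl and changed another place, and they either could not be read or gave only floors within the scatter. No measurement shown gives a cause for the new step.

The compounds shown leave open whether a nitrile, a phenyl ring or a longer alkynyl chain at this place would give a similar number. They also leave open whether ethynyl gives the same step with methylamino or methylsulfanyl on the shared core.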